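The compounds below may be only part of what the source reports. "The series", "measured", "known", "first", "only" and "open" are said of these compounds alone.

Of the compounds shown here, two of one series have so far been measured in a functional assay on MCF7 cells (Homo sapiens) for cytotoxicity, read by MTT assay, with a stated time of 48 h; on this read-out lower numbers stand for stronger inhibition and higher numbers for weaker inhibition. Compound 1 `COc1cc(-c2nnc3n2NC(c2ccco2)C(C(=O)c2ccc(Cl)cc2)S3)cc(OC)c1OC` carries a (4-chlorophenyl)carbonyl group on the shared core. In this assay compound 1 gives only a limit, > 100000 nM, and not a number, as set out in the limit of > 100000 nM in this assay, at which 1 of the 2 values shown sits. Among the compounds with values here, compound 2 `COc1cc(C(=O)C2Sc3nnc(-c4cc(OC)c(OC)c(OC)c4)n3NC2c2cccs2)cc(OC)c1OC` differs from compound 1 in more than one place; in this assay compound 2 gives 71000 nM, and since no single step links the two, their two results simply stand side by side. Compound 3 `COc1cc(-c2nnc3n2NC(c2ccco2)C(C(=O)c2ccc(O)cc2)S3)cc(OC)c1OC` has not yet been measured. It differs from compound 1 by hydroxy in place of chloro on an aromatic carbon. Within the data shown here, no measured pair shows what such a swap does in this assay, and compound 1 itself offers only a limit as a starting point. The expectation for compound 3 is that the step of an at least 1.1-fold lower number from compound 1 to compound 3 (0.04 log units; that floor lies within the scatter) stays within the usual scatter, in no particular direction. Compound 3 is therefore expected to sit at about 90000 nM, in a range from 30000 nM to 300000 nM, with a real chance that this assay again reports only a limit.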

Compound 3, half-maximal inhibitory concentration: 88900 nM
Compound 3: the middle estimate sits 1.0-fold (0.01 log units) above what was measured; the measured number falls inside the stated range.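

In this assay, the swap of chloro for hydroxy on an aromatic carbon, para to a large group, gives this series its first step between two compounds that differ in one place: an at least 1.1-fold lower number from compound 1 to compound 3 (0.05 log units; that floor lies within the scatter). This swap exchanges a group with no hydrogen-bond donor or acceptor for one with one of each, yet the step as printed is only a floor, so it shows no change beyond the usual scatter and does not rule out a larger one. The true size of the step cannot be read, because compound 1 stands only at a limit of the assay: the limit of > 100000 nM in this assay, at which 1 of the 3 values shown sits.

The compounds shown leave open what an amine or a carboxylic acid on this same aromatic carbon would do to the number in this assay. They also leave open how hydroxy in place of chloro would read on a compound of the series whose starting point is a measured number, which would give the step a real size instead of a floor.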